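Swapping Carbamoyl for Aminomethyl on a Second Core

The source may report more compounds than this note shows. Statements on the series, on what has been measured and on what is new or still open speak of the compounds shown alone.

Three compounds have been measured so far:

Compound 1, `NC(=O)c1ccccc1NC(=O)c1cnc2ccccc2c1`, gives 5 ug/mL in a physicochemical assay for solubility; a higher number here means a more soluble compound, a lower number a less soluble compound.
Compound 2, `NCc1ccccc1NC(=O)c1cnc2ccccc2c1`, gives 5 ug/mL in this assay.
Compound 3, `NC(=O)c1ccccc1NC(=O)c1cc2cc([N+](=O)[O-])ccc2s1`, gives 10 ug/mL in this assay.

The first pair differs by a single change, (aminomethyl in place of carbamoyl on an aromatic carbon), and the measured step was no change at the digits printed from compound 1 to compound 2 (within the scatter). Compound 3 is built on a different core; the difference between the two cores is not broken down here, and its value sits close to those of compounds 1 and 2. Compound 4, `NCc1ccccc1NC(=O)c1cc2cc([N+](=O)[O-])ccc2s1`, is not yet measured. It arises from compound 3 by the same change, (aminomethyl in place of carbamoyl on an aromatic carbon), at the same kind of place. Because the earlier step of no change at the digits printed from compound 1 to compound 2 (within the scatter) left the number unmoved, the expected step is no change at the digits printed from compound 3 to compound 4 (within the scatter). Compound 4 is therefore estimated at 10 ug/mL, with a range from 5 ug/mL to 20 ug/mL, resting on a single prior example of this change.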

Compound 4, solubility: 1000 ug/mL
For compound 4 the middle estimate is 100-fold (2.00 log units) below the measured one, outside the stated range (above it).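

In this assay, putting aminomethyl in place of carbamoyl gave a 100-fold higher number from compound 3 to compound 4 (2.00 log units; beyond the scatter) on the second core, whereas on the core of compound 1 the same change gave no change at the digits printed from compound 1 to compound 2 (within the scatter) in the earlier pair. The size of this step therefore did not carry over from one core to the other, so one pair could not predict the other here. These two pairs show that the outcome differed between the cores, but not which feature of the cores lies behind that difference, and no supporting measurement bears on the reason.

The compounds shown leave open whether a carboxylic acid or a longer amine chain in the same place would follow aminomethyl on either core. They also leave open what this change would do on a third core.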